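This account rests on a few compounds, and the source may have more. Where it says the series, first, only, none or still open, it means among the compounds named here.

Compound 1 `CC1(C)[C@H]2CC[C@]1(C)N(Cc1cn(-c3ccc(C#N)cc3)nn1)C(=O)C2`: 90 nM
Compound 2 `CC1(C)[C@H]2CC[C@]1(C)N(Cc1cn(-c3ccccc3F)nn1)C(=O)C2`: 40 nM
Compound 3 `CC1(C)[C@H]2CC[C@]1(C)N(Cc1cn(-c3ccc(F)cc3)nn1)C(=O)C2`: 40 nM

These numbers come from a functional assay on LoVo cells (Homo sapiens) for inhibition, read by MTT assay, with a stated time of 24 h; a lower number here means a stronger inhibitor, a higher number a weaker inhibitor. Compound 2, at 40 nM, stands level with compound 3, and the two share the lowest number of the three. The next structure is compound 4 `CC1(C)[C@H]2CC[C@]1(C)N(Cc1cn(-c3ccc(O)cc3)nn1)C(=O)C2`, which carries 4-hydroxyphenyl in place of 2-fluorophenyl on an aromatic nitrogen.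

Three measured steps change this same group. Two are modest, a 2.3-fold lower number from compound 1 to compound 2 (0.35 log units; beyond the scatter) and a 2.3-fold lower number from compound 1 to compound 3 (0.35 log units; beyond the scatter), while no change at the digits printed from compound 2 to compound 3 (within the scatter) shows no shift. Within the data shown here, no measured compound carries a hydroxyl group, so these steps offer only a guide to size. Among the measured compounds shown here, a modest step is therefore expected in this assay, more likely towards a higher number, since the only measured compound without fluorine, compound 1, gives 90 nM.

In numbers, a 1.5-fold higher number from compound 2 to compound 4 (0.18 log units; within the scatter) is the expected step. For compound 4 the estimated value is 60 nM, with an expected range of 20 nM to 200 nM.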

Compound 4, half-maximal inhibitory concentration: 410 nM
Estimate against measurement, compound 4: 6.8-fold (0.83 log units) below; measured number above the stated range.
By their numbers in this assay, from the lowest: compounds 2 and 3 (each within the scatter of the next); then compound 1; then compound 4.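

Among these compounds, the group on the aromatic nitrogen can matter far more than the earlier compounds suggested: the change to 4-hydroxyphenyl gives a 10-fold higher number from compound 2 to compound 4 (1.01 log units; beyond the scatter) and likewise a 10-fold higher number from compound 3 to compound 4 (1.01 log units; beyond the scatter), both larger than any step seen before at this position. Hydroxy also compares poorly with cyano, with a 4.6-fold higher number from compound 1 to compound 4 (0.66 log units; beyond the scatter), which makes compound 4 the weakest inhibitor of the four, so the earlier gap between cyano and fluoro was only a small part of the range this position can span. Nothing available here explains why this swap has so large an effect.

Going by these compounds, it remains open whether a methoxy group or an amine in the place of the hydroxy would give a number close to that of compound 4 or closer to those of the fluoro compounds. The compounds shown also cannot tell whether a carboxylic acid there would push the number higher still.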